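Chain extension from compound 3 to compound 4

The source may report more compounds than this note shows. Statements on the series, on what has been measured and on what is new or still open speak of the compounds shown alone.

In a functional assay on CNE-2 cells (Homo sapiens) for inhibition, read by MTT assay, with a stated time of 72 h (on this read-out lower numbers stand for stronger inhibition and higher numbers for weaker inhibition), compound 1 `Nc1ncnc2c1c(-c1cnc3[nH]ccc3c1)nn2CCCCCCCCC(=O)NO` reads 2270 nM and compound 2 `Nc1nc2cc(-c3nn(CCCCCCCCCC(=O)NO)c4ncnc(N)c34)ccc2o1` reads 36800 nM while compound 3 `Nc1nc2cc(-c3nn(CCCCCC(=O)NO)c4ncnc(N)c34)ccc2o1` reads 37600 nM on the same scale. Compound 3 thus sits level with compound 2, and its number is clearly higher than that of compound 1.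

The change to compound 4 `Nc1nc2cc(-c3nn(CCCCCCCCC(=O)NO)c4ncnc(N)c34)ccc2o1` is counted as 3-(hydroxycarbamoyl)propyl in place of hydroxycarbamoyl on a saturated chain carbon, five bonds along the chain from an aromatic nitrogen and reads in words: 3-(hydroxycarbamoyl)propyl in place of hydroxycarbamoyl on a saturated chain carbon, five bonds along the chain from an aromatic nitrogen.

Going by the values given here, one measured step bears on it, namely a 1.0-fold higher number from compound 2 to compound 3 (0.01 log units; within the scatter) at the same place, where hydroxycarbamoyl stands in place of 4-(hydroxycarbamoyl)butyl. The chain of compound 4 is intermediate in length between those of compound 3 and compound 2, so both neighbours in chain length are already measured and do not differ beyond the scatter. That pair says nothing directly about the lengths between its two ends, which keeps the range wide.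

What is expected in this assay is no change beyond the scatter, with the estimate at a 1.5-fold lower number from compound 3 to compound 4 (0.18 log units; within the scatter) and only a slight lean to a lower number. The estimated value for compound 4 is 25000 nM with an expected range from 8000 nM to 60000 nM in this read-out.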

Compound 4, half-maximal inhibitory concentration: 3240 nM
Estimate against measurement, compound 4: 7.7-fold (0.89 log units) above; measured number below the stated range.
By their numbers in this assay, from the lowest: compounds 1 and 4 (each within the scatter of the next); then compounds 2 and 3 (each within the scatter of the next).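

In this assay the response to chain length at this position proves not to be flat: the 3-(hydroxycarbamoyl)propyl extension gives a 12-fold lower number from compound 3 to compound 4 (1.06 log units; beyond the scatter) and, from the long end of the series, taking away the (hydroxycarbamoyl)methyl end of the chain in favour of hydroxycarbamoyl gives an 11-fold lower number from compound 2 to compound 4 (1.06 log units; beyond the scatter). The level reading of the two other chain lengths, a 1.0-fold higher number from compound 2 to compound 3 (0.01 log units; within the scatter), therefore hid a large drop in the number at the chain of compound 4, a pattern that rests on these three compounds alone. At this chain length the exchange of the group on the aromatic carbon gives a 1.4-fold higher number from compound 1 to compound 4 (0.15 log units; within the scatter), so the two aromatic groups read alike here, and no measurement at hand accounts for the large steps.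

The compounds shown leave open how narrow the drop is, since the shorter chains between those of compound 3 and compound 4 would show whether the number falls gradually or abruptly. Also open, going by these compounds, is whether the chain end must be the hydroxycarbamoyl group, which a carboxylic acid or a primary amide at the same chain end would test.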